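Methoxy for Methyl: What Compound 4 Should Show

The source may hold more compounds than are shown below. What is called first, only, known or untested is meant among the compounds shown, and "the series" means these compounds.

Compound 1 `Cc1ccc(-c2nn(-c3ccc(Cl)cc3)cc2C=O)cc1` and compound 2 `COc1ccc(-c2nn(-c3ccc(Cl)cc3)cc2C=O)cc1` share one core and differ only by methoxy in place of methyl on an aromatic carbon. In a functional assay on the whole organism (strain Wistar albino) for inhibition, with Rattus norvegicus as the target, read by paw edema, with stated times of 1 h and 3 h, at a dose of 0.32 mmol/kg by the intraperitoneal route (a higher number here means more inhibition at the dose given (going by the name of the read-out), a lower number less inhibition), compound 1 gives 56%, and compound 2 gives 57.6%; the step is a number 1.6 percentage points higher from compound 1 to compound 2 (within the scatter). Compound 3 `Cc1ccc(-c2nn(-c3ccc(Cl)cc3)cc2/C=C\C(=O)c2ccc(Cl)cc2)cc1` differs from compound 1 in more than one place, and the difference between the two cores is not broken down here. In this assay compound 3 gives 61.4%, a value within the scatter of both compound 1 and compound 2. Within the data shown here, compound 4 `COc1ccc(-c2nn(-c3ccc(Cl)cc3)cc2/C=C\C(=O)c2ccc(Cl)cc2)cc1` differs from compound 3 by methoxy in place of methyl on an aromatic carbon, the same change at the same place as the one from compound 1 to compound 2. Because a number 1.6 percentage points higher from compound 1 to compound 2 (within the scatter) stayed within the scatter, a step of similar size, a number 1.6 percentage points higher from compound 3 to compound 4 (within the scatter), is expected. Compound 4 is therefore estimated at 63%, between 54% and 72%.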

Compound 4, a percentage reported as inhibition, in the whole organism at one dose (the size of the read-out at that dose, not a potency): 66.4%
For compound 4 the middle estimate is 3.4 percentage points below the measured one, and the stated range covers the measured number.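

In this assay the change from 4-methylphenyl to 4-methoxyphenyl gives a number 5 percentage points higher from compound 3 to compound 4 (within the scatter) on the core of compound 3, and this step does not differ from the one on the core of compound 1: the same change on two cores in this assay, a number 1.6 percentage points higher (within the scatter) from compound 1 to compound 2 and a number 5 percentage points higher (within the scatter) from compound 3 to compound 4, 3.4 percentage points apart, within the scatter of two such steps. The change therefore carried across these two cores without a gap beyond the scatter. Neither step itself stands clear of the scatter, however, so the pair does not show that methoxy gives more inhibition than methyl on either core, and two cores cannot establish a rule for the wider series.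

The compounds shown leave open how an amine or a carboxylic acid would read at this place. They also leave open a longer chain on the oxygen, such as ethoxy.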